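The source may hold more compounds than are shown below. What is called first, only, known or untested is meant among the compounds shown, and "the series" means these compounds.

The measured compounds and their values:

Compound 1, `Nc1cc(N)c2nc(-c3ccccc3)c(NCc3ccc(Cl)c(Cl)c3)nc2c1`, gives 95500 nM in a functional assay on NCI-H226 cells (Homo sapiens) for inhibition, read by sulforhodamine B assay, with a stated time of 48 h; on this read-out lower numbers stand for higher toxicity in this test and higher numbers for lower toxicity in this test.
Compound 2, `COc1ccc(CNc2nc3cc(N)cc(N)c3nc2-c2ccccc2)cc1OC`, gives 64600 nM.
Compound 3, `CCOC(=O)[C@H](CCC(=O)O)NC(=O)c1ccc(Sc2nc3cc(N)cc(N)c3nc2-c2ccccc2)cc1`, reaches only a limit of the assay, < 100000 nM; this is the limit of < 100000 nM in this assay, at which 1 of the 3 values shown sits.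

Compound 2 has the lowest of the two numbers, but its nearest neighbour, compound 1, differs by only a 1.5-fold lower number from compound 1 to compound 2 (0.17 log units; within the scatter), so the two cannot be told apart. Compound 4, `COc1cc(CNc2nc3cc(N)cc(N)c3nc2-c2ccccc2)cc(OC)c1OC`, differs from compound 2 by methoxy in place of hydrogen on an aromatic carbon. Within the data shown here, only one measured step bears on this change: the swap from compound 1 to compound 2, which exchanged one ring for another on the same saturated chain carbon and stayed within the scatter. With that single, flat comparison, compound 4 is expected to show no step beyond the scatter, and the estimate for compound 4 is 60000 nM, with a range from 25000 nM to 150000 nM, which means an expected step of a 1.1-fold lower number from compound 2 to compound 4 (0.03 log units; within the scatter).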

Compound 4, concentration lethal to 50% of the cells: < 50200 nM
Compound 4 ended at the assay's limit (the forecaster's own chance of this, stated with the estimate: 30%); at least 1.1-fold (0.07 log units) between middle value and limit.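

In this assay compound 4 gives no number, only a limit of the assay: the limit of < 50200 nM in this assay, at which 1 of the 4 values shown sits. The earlier step exchanged one whole substituted ring for another, whereas this one adds a single methoxy at one aromatic carbon, ortho to a methoxy group, and reads as an at least 1.2-fold lower number from compound 2 to compound 4 (0.10 log units; that floor lies within the scatter) on the shared core. That floor does not separate the two compounds, and the limit leaves the real size of the step unknown, so it may be larger than the floor.

The compounds shown leave open whether another group at this aromatic carbon, such as a hydroxyl, an amine or a carboxylic acid, would give a step beyond the scatter. They also leave open what a longer chain between this ring and the nitrogen would do.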